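A Fluorine on the Benzyl Ester of Compound 3

The source may hold more compounds than are shown below. What is called first, only, known or untested is meant among the compounds shown, and "the series" means these compounds.

Compound 3 `COc1ccc(-c2csc(N)c2C(=O)OCc2ccccc2)cc1OC` stands highest of the three compounds measured in an assay on isolated protein for inhibition of protein kinase C zeta type (Homo sapiens), with stated times of 1 h and 2.5 min, tested at 30 uM; on this read-out higher numbers stand for more inhibition at the one concentration tested (going by the name of the read-out) and lower numbers for less inhibition: compound 3 gives 100%. Its nearest neighbour is compound 1 `CCOC(=O)c1c(-c2ccc(OC)c(OC)c2)csc1N(C)C`, which in this assay gives 60%, a number beyond the scatter below compound 3. Furthest away lies compound 2 `CCOC(=O)c1c(-c2ccc(OC)c(OC)c2)csc1NC(N)=O`, which in this assay gives 14%. Among the compounds with values here, the one step between measured compounds that differ in a single place is a number 46 percentage points lower from compound 1 to compound 2 (beyond the scatter), ureido in place of dimethylamino on an aromatic carbon; it alters the substituent on the shared core and leaves the ester untouched.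

Compound 4 `COc1ccc(-c2csc(N)c2C(=O)OCc2ccccc2F)cc1OC` differs from compound 3 by fluoro in place of hydrogen on an aromatic carbon, on an aromatic carbon of a six-membered aromatic ring of carbon only, ortho to a large group. Within the data shown here, no measured step touches this ring; the large step already described concerns another part of the molecule and offers no guide to the size or direction of a change here. Since compound 3 already sits at the top of the read-out, little room is left upward, and the step is expected to be a number 5 percentage points lower from compound 3 to compound 4 (within the scatter), none beyond the scatter. Compound 4 is therefore estimated at 95%, with a range from 80% to 100%.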

Compound 4, a percentage reported as inhibition, at one concentration (the size of the read-out at that concentration, not a potency): 100%
Beside the measured number, compound 4's estimate is 5 percentage points below it, and the stated range covers the measured number.
By their numbers in this assay, from the lowest: compound 2; then compound 1; then compounds 3 and 4 (each within the scatter of the next).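

Within the data shown here, the first measured change on the benzyl ester ring, phenyl to 2-fluorophenyl, gives no change at the digits printed from compound 3 to compound 4 (within the scatter) in this assay, so this place on an aromatic carbon, ortho to a large group, takes a fluoro with no loss of inhibition that this read-out can show. Unlike the large step among the earlier compounds, which lay on another part of the molecule, this result speaks directly to the ring of the ester, yet compound 3 gives 100% and compound 4 gives 100%, both at the top of the read-out at a single concentration, so any gain from the fluoro would stay out of sight. Nothing shown here offers an explanation for the unchanged number.

The compounds shown leave open whether a group larger than fluoro, such as chloro, methoxy or trifluoromethyl, or an amine in the same place would also hold the number. They also leave open whether compound 3 and compound 4 would part at concentrations low enough for the read-out to fall from its top.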